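Aryloxy and aryl variation at the quinoline-free core, permeability notes

The source may report more compounds than this note shows. Statements on the series, on what has been measured and on what is new or still open speak of the compounds shown alone.

The series shares one core; compound 1 `COc1ccc(F)cc1CNCCCNc1ccnc2cc(Oc3ccc(C(C)(C)C)cc3)ccc12` carries a 4-(tert-butyl)phenoxy group on it. In an ADME assay for permeability, using PAMPA, with a stated time of 30 min, at pH 7.4 (a lower number here means that the compound crosses the layer more slowly, a higher number that the compound crosses the layer faster), compound 1 gives 317 10^-6 cm/s. Compound 2 `COc1ccc(-c2ccc3c(NCCCNCc4cc(F)ccc4OC)ccnc3c2)cc1` gives 237 10^-6 cm/s in this assay, and compound 3 `COc1ccc(F)cc1CNCCCNc1ccnc2cc(-c3ccc(C(F)(F)F)cc3)ccc12` gives 237 10^-6 cm/s. The three values lie close: a 1.3-fold lower number from compound 1 to compound 2 (0.13 log units; within the scatter), a 1.3-fold lower number from compound 1 to compound 3 (0.13 log units; within the scatter) and no change at the digits printed from compound 2 to compound 3 (within the scatter). Compound 3 therefore stands level with compound 2 at the digits shown, and the gap to compound 1 stays within the scatter; no ordering among the three can be read from these numbers.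

Compound 4 `COc1ccc(F)cc1CNCCCNc1ccnc2cc(Oc3ccccc3OC)ccc12` differs from compound 3 in a single place: 2-methoxyphenoxy in place of 4-(trifluoromethyl)phenyl on an aromatic carbon. The step that bears most on it is a 1.3-fold lower number from compound 1 to compound 3 (0.13 log units; within the scatter), where an aryloxy group and an aryl group with different terminal substituents gave numbers within the scatter of one another; no change at the digits printed from compound 2 to compound 3 (within the scatter) shows the same for exchanging the terminal substituent itself. With all three measured steps inside the scatter, no movement in this assay beyond the scatter is expected, and compound 4 is estimated at 230 10^-6 cm/s, with a range from 130 10^-6 cm/s to 400 10^-6 cm/s. The expected step is a 1.0-fold lower number from compound 3 to compound 4 (0.01 log units; within the scatter).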

Compound 4, apparent permeability: 317 10^-6 cm/s
For compound 4 the middle estimate is 1.4-fold (0.14 log units) below the measured one, within the range that was stated.
By their numbers in this assay, from the lowest: compounds 2, 3, 1 and 4 (each within the scatter of the next).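

The 2-methoxyphenoxy group on this aromatic carbon, with 2 hydrogen-bond acceptors where 4-(trifluoromethyl)phenyl has 0, leaves the read-out in this assay within the scatter, both against that group (a 1.3-fold higher number from compound 3 to compound 4 (0.13 log units; within the scatter)) and against 4-methoxyphenyl (a 1.3-fold higher number from compound 2 to compound 4 (0.13 log units; within the scatter)). With the oxygen link kept, the exchange of 4-(tert-butyl)phenyl for 2-methoxyphenyl also gives a step within the scatter (no change at the digits printed from compound 1 to compound 4 (within the scatter)), so the series now holds a direct comparison of two aryloxy groups and not only comparisons of aryloxy with aryl or of one aryl with another. No separate measurement is available to explain any of these steps.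

Every group shown at this position contains a six-membered aromatic ring of carbon only, so it remains open whether a carboxylic acid, a piperidine or a small alkoxy group there would give a step beyond the scatter in this assay. The compounds also leave open whether the flat picture would hold with a longer chain in the shared core, since all four carry the same chain and the same fluorinated methoxybenzyl end.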